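Removing the (4-methylbenzyl)sulfanyl arm of compound 2

The source may report more compounds than this note shows. Statements on the series, on what has been measured and on what is new or still open speak of the compounds shown alone.

Compound 2 `Cc1ccc(CSc2nc3nc(C)cc(Nc4cc(-c5ccccc5)[nH]n4)n3n2)cc1` holds the lowest of the two numbers in hand: in a functional assay on PC-9 cells (Homo sapiens) for inhibition, read by MTT assay, with a stated time of 72 h (a higher number here means a weaker inhibitor, a lower number a stronger inhibitor), compound 2 gives 7310 nM. For the measured compounds named here, its only neighbour is compound 1 `Cc1cc(Nc2cc(-c3ccccc3)[nH]n2)n2nc(SCc3ccc([N+](=O)[O-])cc3)nc2n1`, which in this assay gives 7980 nM; the step of a 1.1-fold lower number from compound 1 to compound 2 (0.04 log units; within the scatter) is within the scatter, so no order between compound 1 and compound 2 is claimed.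

Compound 3 `Cc1cc(Nc2cc(-c3ccccc3)[nH]n2)n2ncnc2n1` is compound 2 with hydrogen in place of (4-methylbenzyl)sulfanyl on an aromatic carbon. The (4-methylbenzyl)sulfanyl group, with its one six-membered aromatic ring of carbon only, is gone, and only a hydrogen remains on the five-membered aromatic ring with 3 nitrogen.

Going by the values given here, no measured step bears directly on this change. Among the compounds with values here, the single step in hand, a 1.1-fold lower number from compound 1 to compound 2 (0.04 log units; within the scatter), exchanges a substituent on the ring that now leaves and says nothing about loss of the whole group. With no guide in the data, removal of this much of the molecule is expected to weaken inhibition, that is to raise the number, by a step of a 2.1-fold higher number from compound 2 to compound 3 (0.31 log units; beyond the scatter). Compound 3 is therefore estimated at 15000 nM in this assay, with a range from 5000 nM to 45000 nM.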

Compound 3, half-maximal inhibitory concentration: > 50000 nM
Compound 3: a limit, no number (the forecaster's own chance of this, stated with the estimate: 15%); middle value at least 3.3-fold (0.52 log units) away from the limit.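

In this assay compound 3 reads as a limit of the assay and not as a number: the limit of > 50000 nM in this assay, at which 1 of the 3 values shown sits.

Hydrogen in place of (4-methylbenzyl)sulfanyl gives an at least 6.8-fold higher number from compound 2 to compound 3 (0.83 log units; beyond the scatter), and hydrogen in place of (4-nitrobenzyl)sulfanyl gives an at least 6.2-fold higher number from compound 1 to compound 3 (0.79 log units; beyond the scatter), so among these three compounds, the number depends on an arm being present on this aromatic carbon between two ring nitrogen atoms. The exchange of nitro for methyl on the ring of the arm gave only a 1.1-fold lower number from compound 1 to compound 2 (0.04 log units; within the scatter), so the loss of the whole arm registers here, while that exchange on the arm does not.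

The compounds shown leave open which part of the arm carries the difference, the sulfur or the benzyl group with its six-membered aromatic ring, and how far above its limit compound 3 truly lies. A methylsulfanyl group, an amine or a longer alkyl chain on the same aromatic carbon would separate these parts and show whether the aromatic ring of the arm is needed at all.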